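The source may report more compounds than this note shows. Statements on the series, on what has been measured and on what is new or still open speak of the compounds shown alone.

Working notes on the series. Compound 1 `O=C(N/N=C/c1cc(I)cc(I)c1O)c1ccccc1`, compound 2 `Cc1ccc(C(=O)N/N=C/c2cc(I)cc(I)c2O)cc1` and compound 3 `CC(C)(C)c1ccc(C(=O)N/N=C/c2cc(I)cc(I)c2O)cc1` share one core and differ only in the group on an aromatic carbon of a six-membered aromatic ring of carbon only. In a functional assay on HepG2 cells (Homo sapiens) for cytotoxicity, with a stated time of 24 h (on this read-out lower numbers stand for stronger inhibition and higher numbers for weaker inhibition), compound 1 reaches only a limit, > 50000 nM. In this assay compound 2 also reaches only a limit, > 25000 nM. In this assay, among the compounds with values here, compound 3 gives 41600 nM, the only number in the set. The step of an at least 1.2-fold lower number from compound 1 to compound 3 (0.07 log units; that floor lies within the scatter) stays within the scatter. The steps a step that the two limits leave unreadable from compound 1 to compound 2 and a step that the limit leaves unreadable from compound 2 to compound 3 cannot be read, given the limit of > 50000 nM in this assay, at which 1 of the 3 values shown sits, and (the limit of > 25000 nM in this assay, at which 1 of the 3 values shown sits).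

Compound 4 `O=C(N/N=C/c1cc(I)cc(I)c1O)c1ccc(O)cc1` follows from compound 3 by hydroxy in place of tert-butyl on an aromatic carbon. The three measured steps all concern the same position, and the only readable one lies within the scatter, so no change beyond the scatter is expected in this assay. The step expected here is a 1.2-fold higher number from compound 3 to compound 4 (0.08 log units; within the scatter). Compound 4 is estimated at 50000 nM, with a range from 25000 nM to 100000 nM, and a real chance that only a limit is reported.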

Compound 4, half-maximal inhibitory concentration: 19200 nM
Estimate against measurement, compound 4: 2.6-fold (0.42 log units) above; the whole stated range lies above it.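

At this position the group does move the read-out in this assay: hydroxy in place of tert-butyl gives a 2.2-fold lower number from compound 3 to compound 4 (0.34 log units; beyond the scatter), the first step in the series shown to lie beyond the scatter. Hydroxy in place of hydrogen gives an at least 2.6-fold lower number from compound 1 to compound 4 (0.41 log units; beyond the scatter), which is only a floor set by a limit: the limit of > 50000 nM in this assay, at which 1 of the 4 values shown sits. Hydroxy in place of methyl gives an at least 1.3-fold lower number from compound 2 to compound 4 (0.11 log units; that floor lies within the scatter), a floor that stays within the scatter and also rests on a limit: the limit of > 25000 nM in this assay, at which 1 of the 4 values shown sits.

As far as these compounds go, whether a methoxy group, an amine or a carboxylic acid at this position would shift the number as hydroxy does remains open. From the compounds shown here alone, the order among hydrogen, methyl and tert-butyl also remains open, as compound 1 and compound 2 reach only limits.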